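A Chlorophenyl Urea and Its Isomer in Glioma Cells

A few compounds are considered here, and "the series" means these few. Any claim that something is new, unique, unknown or untested is made for them only; others in the source may bear on it.

Three compounds built on a shared core have been run in a functional assay on U-373MG ATCC cells (Homo sapiens) for inhibition, read by MTT assay, with a stated time of 72 h; a higher number here means a weaker inhibitor, a lower number a stronger inhibitor. Compound 1 `CC1(C)CC(NC(=O)Nc2ccc(Cl)cc2)c2cc(Br)ccc2O1` gives 25000 nM in this assay. Compound 2 `O=[N+]([O-])c1ccc(NC(=S)NC2CCOc3ccc(Cl)cc32)cc1` gives 8000 nM, and compound 3 `CC1(C)CC(NC(=S)Nc2cccc(C#N)c2)c2cc(F)ccc2O1` gives 30000 nM. Among these three numbers compound 1 stands second highest; its value and that of compound 3 lie within the usual scatter, while compound 2 sits beyond the scatter at a lower number. Compound 4 `CC1(C)CC(NC(=O)Nc2cccc(Cl)c2)c2cc(Br)ccc2O1` has not yet been measured. It differs from compound 1 in one place: 3-chlorophenyl in place of 4-chlorophenyl on an amide-type nitrogen. Within the data shown here, no measured pair shows this change, so the data give no direct guide to its effect. The expected step is a 1.3-fold lower number from compound 1 to compound 4 (0.10 log units; within the scatter), no larger than the scatter and with no settled direction. Compound 4 is therefore estimated at 20000 nM, in the range 8000 nM to 50000 nM.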

Compound 4, half-maximal inhibitory concentration: 69000 nM
For compound 4 the middle estimate is 3.5-fold (0.54 log units) below the measured one, outside the stated range (above it).
By their numbers in this assay, from the lowest: compound 2; then compounds 1 and 3 (each within the scatter of the next); then compound 4.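

In this assay, 3-chlorophenyl in place of 4-chlorophenyl on an amide-type nitrogen gives a 2.8-fold higher number from compound 1 to compound 4 (0.44 log units; beyond the scatter). Among these compounds, this is the first comparison here that changes one place only, and it shows that the number responds to where the chlorine sits on this phenyl, though the atoms stay the same. No measurement at hand bears on why this step arises.

The compounds shown leave open whether the same change gives a similar step with a thiocarbonyl in place of the carbonyl. They also leave open how a methoxy group or an amine would stand in place of the chlorine.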